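The compounds below may be only part of what the source reports. "The series", "measured", "known", "first", "only" and "open" are said of these compounds alone.

Working notes on a small set of amides tested in an assay on HEK293 cells for agonist activity at transient receptor potential cation channel subfamily M member 8 (Homo sapiens), read by fluorescence and calcium flux, with a stated time of 15 min; a lower number here means that less compound is needed, a higher number that more compound is needed for the effect. Compound 1 `Cc1ccc(OCC(=O)N(Cc2cccs2)c2ccn(C)n2)cc1` gives 855 nM. Compound 2 `CCN(Cc1cccs1)C(=O)c1cc2cc(C)ccc2o1` gives 120 nM, and compound 3 `CCN(Cc1cncs1)C(=O)COc1ccc(C)cc1` gives 1100 nM. Among these three numbers compound 1 stands second highest. The value nearest to compound 1 is that of compound 3, and the gap between them lies within the usual scatter, so the two cannot be told apart. The value furthest from compound 1 is that of compound 2, which is the lower number, and that gap lies beyond the scatter. Going by the values given here, no pair among compounds 1, 2 and 3 differs in only one place, so only the bare values can be set side by side.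

Compound 4 `Cc1ccc(OCC(=O)N(Cc2cccs2)c2ccnn2C)cc1` has not yet been measured. Relative to compound 1 the change is 1-methyl-1H-pyrazol-5-yl in place of 1-methyl-1H-pyrazol-3-yl on an amide-type nitrogen. Nothing in the measured set bears on a swap of the attachment point of a ring on the amide nitrogen. The step expected from compound 1 to compound 4 is a 1.2-fold higher number from compound 1 to compound 4 (0.07 log units; within the scatter), with no direction favoured and nothing expected beyond the scatter. Compound 4 is estimated at 1000 nM in this assay, with a range from 300 nM to 3500 nM.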

Compound 4, half-maximal effective concentration: 422 nM
Estimate against measurement, compound 4: 2.4-fold (0.37 log units) above; low and high end bracket the measured number.
By their numbers in this assay, from the lowest: compound 2; then compound 4; then compounds 1 and 3 (each within the scatter of the next).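

In this assay, going by these compounds alone, with 1-methyl-1H-pyrazol-5-yl in place of 1-methyl-1H-pyrazol-3-yl on the amide-type nitrogen, the series shows a 2.0-fold lower number from compound 1 to compound 4 (0.31 log units; beyond the scatter) and gives the first reading of a change made in one place. The step is modest, but it shows that this position can respond to the attachment point of the ring alone, since the two groups have the same atoms, joined differently, and the same counts of heavy atoms, hydrogen-bond donors and hydrogen-bond acceptors. The data at hand offer no measured property that would account for this difference.

Going by these compounds, whether 1-methyl-1H-pyrazol-4-yl, the remaining attachment point of this ring, or a phenyl or pyridin-3-yl ring on the same nitrogen would continue this trend or break from it stays open. On these data alone, it is equally open whether the same swap of attachment point gives a step of similar size and direction when the thiophen-2-ylmethyl group on that nitrogen is replaced by a benzyl group, as one step on one pair cannot establish a wider pattern.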